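Ester chain length and cytotoxicity of cytidine esters

The source may hold more compounds than are shown below. What is called first, only, known or untested is meant among the compounds shown, and "the series" means these compounds.

Measured compounds:
compound 1 `CCCCCCCCCC(=O)O[C@H]1[C@H](O)[C@H](n2ccc(N)nc2=O)O[C@@H]1CO` gives 0.09 ug/mL in a functional assay on HeLa cells (Homo sapiens) for cytotoxicity, read by cell counting, with a stated time of 48 h; a lower number here means that less compound is needed, a higher number that more compound is needed for the effect
compound 2 `CCCCCC(=O)O[C@H]1[C@H](O)[C@H](n2ccc(N)nc2=O)O[C@@H]1CO` gives 0.05 ug/mL
compound 3 `CCCCCCCC(=O)O[C@H]1[C@H](O)[C@H](n2ccc(N)nc2=O)O[C@@H]1CO` gives 0.1 ug/mL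

Compound 3 has the highest number of the three, but its gap to compound 1 and to compound 2 is within the scatter, so no order can be read from these values. Compound 4 `CCCCCCC/C=C\C(=O)O[C@H]1[C@H](O)[C@H](n2ccc(N)nc2=O)O[C@@H]1CO` is unmeasured; it differs from compound 3 by a group of 9 heavy atoms (9 carbon; no ring) in place of a group of 7 heavy atoms (7 carbon; no ring), on a carbonyl carbon. All three measured steps change the ester chain and stay within the scatter: a 1.8-fold lower number from compound 1 to compound 2 (0.26 log units; within the scatter), a 1.1-fold higher number from compound 1 to compound 3 (0.05 log units; within the scatter), a 2.0-fold higher number from compound 2 to compound 3 (0.30 log units; within the scatter). Nothing here tests a double bond. Compound 4 is therefore expected to show no step beyond the scatter, a 1.1-fold lower number from compound 3 to compound 4 (0.05 log units; within the scatter). The estimate for compound 4 is 0.09 ug/mL, ranging from 0.04 ug/mL to 0.2 ug/mL.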

Compound 4, concentration for half-maximal effect: 0.06 ug/mL
For compound 4 the middle estimate is 1.5-fold (0.18 log units) above the measured one; low and high end bracket the measured number.
By their numbers in this assay, from the lowest: compounds 2, 4, 1 and 3 (each within the scatter of the next).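

On this carbonyl carbon, a chain with a double bond stays within the scatter of the saturated chains in this assay (a 1.7-fold lower number from compound 3 to compound 4 (0.22 log units; within the scatter)) and (a 1.2-fold higher number from compound 2 to compound 4 (0.08 log units; within the scatter)). The closest comparison is with compound 1, whose chain has the same heavy-atom count, so this pair comes nearest to testing the double bond alone, and it too stays within the scatter (a 1.5-fold lower number from compound 1 to compound 4 (0.18 log units; within the scatter)). No measurement here offers an explanation for this result. Going by these compounds, whether a much longer chain, or a chain carrying an amine or a carboxylic acid, would move the number beyond the scatter remains open.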